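Notes on compound 4: 1-benzofuran-2-yl for thiophen-3-yl

The compounds below may be only part of what the source reports. "The series", "measured", "known", "first", "only" and "open" are said of these compounds alone.

Values in an ADME assay on BJ cells (Homo sapiens) for cytotoxicity, read by MTT assay, with a stated time of 72 h (a higher number here means that more compound is tolerated, a lower number that less compound is tolerated), follow.
- Compound 1 `CCCCCCCCCCCCCCCCCCOP(=O)(O)OC[C@H]1O[C@@H](n2ccc3c(-c4ccoc4)ncnc32)[C@H](O)[C@@H]1O` gives 44200 nM.
- Compound 2 `CCCCCCCCCCCCCCCCCCOP(=O)(O)OC[C@H]1O[C@@H](n2ccc3c(-c4cccs4)ncnc32)[C@H](O)[C@@H]1O` has the entry "not determined" (no result reported).
- Compound 3 `CCCCCCCCCCCCCCCCCCOP(=O)(O)OC[C@H]1O[C@@H](n2ccc3c(-c4ccsc4)ncnc32)[C@H](O)[C@@H]1O` gives > 50000 nM, which is a limit of the assay.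
- Compound 4 `CCCCCCCCCCCCCCCCCCOP(=O)(O)OC[C@H]1O[C@@H](n2ccc3c(-c4cc5ccccc5o4)ncnc32)[C@H](O)[C@@H]1O` has not yet been measured.

Compound 3 has no single number and stands only at a limit: the limit of > 50000 nM in this assay, at which 1 of the 3 values shown sits.

The change to compound 4 is 1-benzofuran-2-yl in place of thiophen-3-yl on an aromatic carbon. The attachment lies on a six-membered aromatic ring with 2 nitrogen, part of a fused or bridged system of two rings.

Among the measured compounds shown here, only one measured step bears on this change: an at least 1.1-fold higher number from compound 1 to compound 3 (0.05 log units; that floor lies within the scatter). It exchanges one five-membered aromatic ring for another and stays within the scatter, so it offers no sign of sensitivity to the group at this place. For the measured compounds named here, no measured compound carries a six-membered aromatic ring of carbon only in this group, so the guidance is indirect. In this assay, no step beyond the scatter is the central expectation, with the wider uncertainty on the lower side.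

The expected step is an at least 1.2-fold lower number from compound 3 to compound 4 (0.09 log units; that floor lies within the scatter).

For compound 4 the estimated value is 40000 nM, with an expected range from 15000 nM to 50000 nM.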

Compound 4, half-maximal cytotoxic concentration: > 50000 nM
Compound 4 gave a limit, no number (the forecaster's own chance of this, stated with the estimate: 50%); middle value at least 1.2-fold (0.09 log units) from the limit.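

In this assay, the step with 1-benzofuran-2-yl in place of furan-3-yl is an at least 1.1-fold higher number from compound 1 to compound 4 (0.05 log units; that floor lies within the scatter), so adding a six-membered aromatic ring of carbon only to this place on the core brings no readable loss of tolerance against compound 1. Compound 4 gives > 50000 nM, which is a limit of the assay. The step from thiophen-3-yl to 1-benzofuran-2-yl cannot be read, and tolerance in this series is now capped by the top of the tested range: the limit of > 50000 nM in this assay, at which 2 of the 4 values shown sit.

As far as these compounds go, how far compound 3 and compound 4 lie beyond that limit stays unknown, so any difference between thiophen-3-yl and 1-benzofuran-2-yl remains hidden. The compounds shown also leave open whether the tolerance at this place holds for an amine or a carboxylic acid, as every group here is an uncharged aromatic ring system.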